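The source may hold more compounds than are shown below. What is called first, only, known or untested is meant among the compounds shown, and "the series" means these compounds.

Compound 1 `CCCNC(=O)/N=C(\N)NCCCc1sc(N)nc1C` was examined in an assay on membranes from Sf9 cells for displacement of a labelled ligand from histamine H2 receptor (Homo sapiens), read by scintillation counting, with a stated time of 60 min (a higher number here means a weaker inhibitor, a lower number a stronger inhibitor), where compound 1 gives 105 nM. Two companions share its core and differ from it only on a saturated chain carbon of the propyl end. Compound 2 `Cc1nc(N)sc1CCCN/C(N)=N/C(=O)NCC(C)CC1CCCCC1` gives 70.8 nM in this assay, and compound 3 `Cc1ccc(CC(C)CNC(=O)/N=C(\N)NCCCc2sc(N)nc2C)cc1` gives 72.4 nM. The step of a 1.5-fold lower number from compound 1 to compound 2 (0.17 log units; within the scatter) and the step of a 1.5-fold lower number from compound 1 to compound 3 (0.16 log units; within the scatter) both fall within the scatter, as does a 1.0-fold higher number from compound 2 to compound 3 (0.01 log units; within the scatter); the three numbers are therefore not separable from one another, and compound 1 cannot be set apart from either companion on the evidence at hand.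

Compound 4 `Cc1nc(N)sc1CCCN/C(N)=N/C(=O)Nc1ccccc1` is the next member: phenyl in place of propyl on an amide-type nitrogen, a difference that, cut one bond further out, reads propylamino to anilino. For the measured compounds named here, none of the measured steps touches this nitrogen itself; they only show that attaching a cyclohexylmethyl or a 4-methylbenzyl further along the chain, as in compound 2 and compound 3, kept the number within the scatter of compound 1. On that basis no step beyond the scatter is expected in this assay for compound 4 either, and the expected step is a 1.2-fold lower number from compound 1 to compound 4 (0.07 log units; within the scatter). Compound 4 is thus estimated to give 90 nM, with a range from 35 nM to 250 nM.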

Compound 4, inhibition constant: 3160 nM
The estimate for compound 4 lay 35-fold (1.55 log units) below the measured number; the measured number lies above the stated range.
By their numbers in this assay, from the lowest: compounds 2, 3 and 1 (each within the scatter of the next); then compound 4.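

In this assay, the amide-type nitrogen turns out to be sensitive to what it carries: phenyl in place of propyl there gives a 30-fold higher number from compound 1 to compound 4 (1.48 log units; beyond the scatter), the only step among these compounds that lies beyond the scatter. The earlier steps shown here had left a saturated chain on this nitrogen and changed only a carbon further along it, and even the aromatic ring of the 4-methylbenzyl group in compound 3 stayed within the scatter of compound 1, so an aromatic ring as such does not go with the higher number; in these compounds, the higher number appears only with the ring standing directly on the nitrogen. No measurement at hand accounts for this step.

A single compound with a ring on this nitrogen cannot show whether the higher number goes with the aromatic ring itself or simply with the loss of the propyl chain. A cyclohexyl group on the same nitrogen would address that question, and a benzyl group there would show whether one saturated carbon between the nitrogen and the ring is enough to bring the number back towards that of compound 1.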